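Replacing the hydroxyethyl sulfonamide substituent with cyclopentyl

The source may report more compounds than this note shows. Statements on the series, on what has been measured and on what is new or still open speak of the compounds shown alone.

Measured compounds:
compound 1 `CCCNS(=O)(=O)c1ccc(Nc2ncc3c(n2)N(C2CCCC2)[C@H](CC)C(=O)N3C)cc1`, 563 nM
compound 2 `CCC1C(=O)N(C)c2cnc(-n3ccc4cc(C(N)=O)ccc43)nc2N1c1ccn(C)n1`, 39500 nM
compound 3 `CC[C@@H]1C(=O)N(C)c2cnc(Nc3ccc(S(=O)(=O)NCCO)cc3)nc2N1C1CCCC1`, 563 nM

In a functional assay on A549 cells (Homo sapiens) for antiproliferative activity, read by CCK-8 assay, with a stated time of 72 h (on this read-out higher numbers stand for weaker inhibition of growth and lower numbers for stronger inhibition of growth), compound 3 gives 563 nM, level with compound 1 and, together with it, the lowest of the three numbers; compound 2 sits far higher. Compound 4 `CC[C@@H]1C(=O)N(C)c2cnc(Nc3ccc(S(=O)(=O)NC4CCCC4)cc3)nc2N1C1CCCC1` has not yet been measured. Its change from compound 3 is cyclopentyl in place of 2-hydroxyethyl on a sulfonamide nitrogen. Going by the values given here, the one step that bears on this position, no change at the digits printed from compound 1 to compound 3 (within the scatter), shows that a change on the sulfonamide nitrogen left the number unchanged, so compound 3 and compound 1 give no ground for a shift beyond the scatter. Compound 4 is therefore expected to give about 450 nM, within 150 nM to 1500 nM, and the expected step of a 1.3-fold lower number from compound 3 to compound 4 (0.10 log units; within the scatter) is estimated to stay within the scatter.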

Compound 4, concentration for 50% growth inhibition: 1150 nM
For compound 4 the middle estimate is 2.6-fold (0.41 log units) below the measured one, within the range that was stated.
By their numbers in this assay, from the lowest: compounds 1 and 3 (each within the scatter of the next); then compound 4; then compound 2.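

In this assay cyclopentyl on the sulfonamide nitrogen, in place of 2-hydroxyethyl, gives a 2.0-fold higher number from compound 3 to compound 4 (0.31 log units; beyond the scatter) and, in place of propyl, gives a 2.0-fold higher number from compound 1 to compound 4 (0.31 log units; beyond the scatter) as well. Both steps are modest, yet they show that the number at this position can move with the substituent, which the level pair of compound 1 and compound 3 had not shown. Nothing given here accounts for the shift.

Going by these compounds, whether the ring itself matters stays open: cyclopropyl or an open branched chain such as isopropyl could side with either compound 4 or the pair. On these data alone, the effect of an amine at the end of the chain also remains open.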